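This account rests on a few compounds, and the source may have more. Where it says the series, first, only, none or still open, it means among the compounds named here.

The measured compounds:

compound 1, `COc1ccc(C2=NN(C(=O)C3COc4ccccc4O3)C(c3cccc(F)c3)C2)cc1` — 6720 nM
compound 2, `COc1ccc(C2=NN(C(=O)C3COc4ccccc4O3)C(c3ccc(F)cc3)C2)cc1` — 6190 nM
compound 3, `O=C(c1ccc2c(c1)OCCO2)N1N=C(c2ccccc2)CC1c1ccc(F)cc1` — 5210 nM

All three were tested in a functional assay on WM 266-4 cells (Homo sapiens) for inhibition, read by MTT assay, with a stated time of 24 h; a lower number here means a stronger inhibitor of growth, a higher number a weaker inhibitor of growth. Compound 1 and compound 2 share one core and differ in a single place: 3-fluorophenyl in place of 4-fluorophenyl on a saturated ring carbon. That change made a step of a 1.1-fold higher number from compound 2 to compound 1 (0.04 log units; within the scatter), so the two values sit together within the usual scatter of the measurement. Compound 3 carries a different core; the difference between the two cores is not broken down here. Its value and that of compound 2 also lie within the scatter of each other, and the same holds for compound 3 against compound 1, so no order among the three can be read from these numbers.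

Compound 4, `O=C(c1ccc2c(c1)OCCO2)N1N=C(c2ccccc2)CC1c1cccc(F)c1`, is not yet measured. It stands to compound 3 as compound 1 stands to compound 2: 3-fluorophenyl in place of 4-fluorophenyl on a saturated ring carbon. The surroundings of the place are not identical, since the ring atom two ring bonds away bears a phenyl group in compound 3 where it bears a 4-methoxyphenyl group in compound 2, so this is the same kind of change rather than the same change. For compound 4 the expected step is a 1.1-fold higher number from compound 3 to compound 4 (0.04 log units; within the scatter), resting on the step seen from compound 2 to compound 1, a 1.1-fold higher number from compound 2 to compound 1 (0.04 log units; within the scatter), which lay within the scatter. Compound 4 is therefore estimated at 5700 nM in this assay, with a likely range from 3000 nM to 11000 nM.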

Compound 4, concentration for 50% growth inhibition: 1840 nM
For compound 4 the middle estimate is 3.1-fold (0.49 log units) above the measured one; the measured number lies below the stated range.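

In this assay, putting 3-fluorophenyl in place of 4-fluorophenyl on the saturated ring carbon of the core of compound 3 gave a modest gain in growth inhibition, a 2.8-fold lower number from compound 3 to compound 4 (0.45 log units; beyond the scatter), whereas on the core of compound 2 the same change gave a step within the scatter, a 1.1-fold higher number from compound 2 to compound 1 (0.04 log units; within the scatter). The effect of this change therefore did not carry from one core to the other in this series, and the step seen on one core could not be taken as a guide to the step on the other: the same change on two cores in this assay, a 1.1-fold higher number (0.04 log units; within the scatter) from compound 2 to compound 1 and a 2.8-fold lower number (0.45 log units; beyond the scatter) from compound 3 to compound 4, 3.1-fold (0.49 log units) apart, beyond the scatter of two such steps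

This does not show which difference between the cores separates the two steps, since the ring atom bears a phenyl group in compound 3 and a 4-methoxyphenyl group in compound 2 and the cores differ elsewhere as well, and one pair on each core gives no rule for any further core.

The compounds shown leave open whether the step on the core of compound 3 belongs to the fluorophenyl groups alone or would also appear with a chlorophenyl group on the same saturated ring carbon. They also leave open how a phenyl group carrying an amine or a carboxylic acid would behave at that place on either core.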